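Notes on the sulfonyl substituent series, compound 2 to 3

The compounds below may be only part of what the source reports. "The series", "measured", "known", "first", "only" and "open" are said of these compounds alone.

Compound 2 `CC(=O)NCCS(=O)(=O)NC(=O)c1ccc(Nc2nc(NC3(c4ccc(Cl)cc4)CC3)nc(OCC(F)(F)F)n2)cc1` carries a 2-acetamidoethyl group on the sulfonyl sulfur; in an ADME assay on microsomes from liver (Homo sapiens) for metabolic stability, with a stated time of 10 min (on this read-out higher numbers stand for a more stable compound and lower numbers for a less stable compound), compound 2 gives 95%. Among the compounds with values here, its only measured neighbour is compound 1 `O=C(NS(=O)(=O)c1ccccc1)c1ccc(Nc2nc(NC3(c4ccc(Cl)cc4)CC3)nc(OCC(F)(F)F)n2)cc1`, which bears phenyl at the same position and in this assay gives 100%. Within the data shown here, the step between them, a number 5 percentage points lower from compound 1 to compound 2 (within the scatter), is the sole measured step in the set, and it leaves compound 2 standing within the scatter of compound 1, the only other number available.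

Compound 3 `O=C(NS(=O)(=O)CCNCc1ccccc1)c1ccc(Nc2nc(NC3(c4ccc(Cl)cc4)CC3)nc(OCC(F)(F)F)n2)cc1` differs from compound 2 in one place: benzyl in place of acetyl on an amine nitrogen. Among the measured compounds shown here, no measured step touches an amine nitrogen or exchanges an acetyl for a benzyl, so the numbers give nothing to fix the size or direction of this change; the only anchor is the value of compound 2, which itself sits within scatter of compound 1. Compound 3 is therefore expected to remain near the top of the read-out, with the step of a number 10 percentage points lower from compound 2 to compound 3 (within the scatter) estimated as at most a modest loss. In this assay compound 3 is estimated at 85%, within a range from 55% to 100%.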

Compound 3, percent of the compound remaining: 99%
Compound 3: middle estimate off by 14 percentage points, on the low side, and the stated range covers the measured number.
By their numbers in this assay, from the lowest: compounds 2, 3 and 1 (each within the scatter of the next).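

In this assay the exchange on the amine nitrogen reads a number 4 percentage points higher from compound 2 to compound 3 (within the scatter) and so gives the series its first measured step at this nitrogen, where benzyl, with its six-membered aromatic ring of carbon only, cannot be told apart from acetyl. Read back to the sulfonyl sulfur, the same compound gives a number 1 percentage points lower from compound 1 to compound 3 (within the scatter) and thereby adds 2-(benzylamino)ethyl to phenyl and 2-acetamidoethyl as a third substituent on that sulfur, with all three lying within the scatter of one another. No measurement is available that would account for this flat picture.

Still open, on these data alone, is whether this tolerance extends to a free primary amine at the end of the ethyl chain, or to a carboxylic acid or a longer chain on the sulfonyl sulfur. Compounds 1, 2 and 3 cannot be separated in this assay and so offer no ranking of these substituents, which leaves any group that would bring the read-out clearly down still to be identified.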